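A Methyl on the Imidazole of a Fast-Cleared Compound

The source may report more compounds than this note shows. Statements on the series, on what has been measured and on what is new or still open speak of the compounds shown alone.

Compound 1 `CC(C)C(c1ncc[nH]1)c1ccc(-c2ccc3cccc(F)c3c2)[nH]c1=O` was tested in an ADME assay on microsomes from liver (Mus musculus) for metabolic stability; a lower number here means that the compound disappears faster, a higher number that the compound lasts longer. In this assay compound 1 gives < 0.0667 h, which is a limit of the assay and not a number. Its close relative compound 2 `CC(C)C(Cc1ncc[nH]1)c1ccc(-c2ccc3cccc(F)c3c2)[nH]c1=O` gives in this assay < 0.0667 h, again a limit rather than a number. Within the data shown here, the one measured step, a step that the two limits leave unreadable from compound 1 to compound 2, therefore cannot be read in size or direction; what the two results share is the limit of < 0.0667 h in this assay, at which 2 of the 2 values shown sit. Compound 3 `Cc1c[nH]c(C(c2ccc(-c3ccc4cccc(F)c4c3)[nH]c2=O)C(C)C)n1` differs from compound 1 by methyl in place of hydrogen on an aromatic carbon. No measured step covers this change, and compound 1 itself stands only at a limit, so there is no direction to read from the numbers shown. The step expected here is a step that the limit leaves unreadable from compound 1 to compound 3. Compound 3 is estimated at 0.05 h in this assay, within a range from 0.02 h to 0.15 h.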

Compound 3, half-life: < 0.0667 h
Compound 3 gave a limit, no number (the forecaster's own chance of this, stated with the estimate: 75%); the middle value is on the limit's open side.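

Compound 3 gives a limit and not a number, as do compound 1 and compound 2, so no step among these three can be read: the limit of < 0.0667 h in this assay, at which 3 of the 3 values shown sit.

The compounds shown leave open how long each one actually lasts in this assay, and whether 4-methyl-1H-imidazol-2-yl in place of 1H-imidazol-2-yl changes that at all.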